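A few compounds are considered here, and "the series" means these few. Any claim that something is new, unique, unknown or untested is made for them only; others in the source may bear on it.

In an ADME assay on THP-1 cells (Homo sapiens) for cytotoxicity, read by MTT assay, with a stated time of 72 h (a lower number here means a stronger inhibitor, a higher number a weaker inhibitor), compound 1 `O=C(O)c1ccc(/C=C/C(=O)c2c(O)c3ccccc3[nH]c2=O)cc1` gives > 50000 nM as its result, a limit of the assay and not a number. Compound 2 `CC(/C=C/C(=O)c1c(O)c2ccccc2[nH]c1=O)=C\c1ccccc1` also gives > 50000 nM as its result, again a limit. Within the data shown here, the picture so far is the limit of > 50000 nM in this assay, at which 2 of the 2 values shown sit, and no measured step exists to serve as a guide. Compound 3 `Cc1ccc(/C=C/C(=O)c2c(O)c3ccccc3[nH]c2=O)cc1` carries methyl in place of carboxy on an aromatic carbon, para to a large group (methyl in place of carboxy on an aromatic carbon). In this assay the expected step of an at least 1.2-fold lower number from compound 1 to compound 3 (0.09 log units; that floor lies within the scatter) is small and toward lower numbers, or none beyond the scatter. For compound 3 the estimated value is 40000 nM with 15000 nM to 50000 nM as the expected range.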

Compound 3, half-maximal inhibitory concentration: > 50000 nM
Compound 3: a limit, no number (the forecaster's own chance of this, stated with the estimate: 60%); middle value at least 1.2-fold (0.09 log units) from the limit.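

Among these compounds, compound 1 and compound 3 both give a limit rather than a number, so no step between them can be read. Whether methyl in place of carboxy changes the result in this assay at all stays open, with every compound shown stopping at the same point: the limit of > 50000 nM in this assay, at which 3 of the 3 values shown sit.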